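This account rests on a few compounds, and the source may have more. Where it says the series, first, only, none or still open, it means among the compounds named here.

Of the compounds shown here, two sharing one core have been tested in an assay on isolated protein for displacement of a labelled ligand from metabotropic glutamate receptor 5 (Homo sapiens), with a stated time of 60 min, tested at 1 uM; on this read-out higher numbers stand for more inhibition at the one concentration tested (going by the name of the read-out) and lower numbers for less inhibition. Compound 1 `Cc1ccc(S(=O)(=O)c2cnc3ccc(Cl)cc3c2N2CCC(C)CC2)cc1F` gives 68% in this assay, and compound 2 `CC1CCN(c2c(S(=O)(=O)c3cccc(C#N)c3)cnc3ccc(Cl)cc23)CC1` gives 90%, the higher of the two numbers. For the measured compounds named here, the single measured step, a number 22 percentage points higher from compound 1 to compound 2 (beyond the scatter), is the only guide to how the ring on the sulfonyl sulfur affects this assay. Compound 3 `CC1CCN(c2c(S(=O)(=O)c3ccc(F)c(F)c3)cnc3ccc(Cl)cc23)CC1` changes the same place once more: 3,4-difluorophenyl in place of 3-cyanophenyl on a sulfonyl sulfur. Going by the values given here, compound 1, which also carries a fluorine on the ring in this place, gave the lower number of the pair, so the move away from the 3-cyanophenyl is expected to cost some of the inhibition, though no measured step shows the difluoro ring itself. For compound 3 the estimate in this assay is 75%, with a range from 55% to 92%. This expected step, a number 15 percentage points lower from compound 2 to compound 3 (beyond the scatter), is judged smaller than the measured one.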

Compound 3, a percentage reported as inhibition, at one concentration (the size of the read-out at that concentration, not a potency): 72%
The estimate for compound 3 lay 3 percentage points above the measured number; low and high end bracket the measured number.
By their numbers in this assay, from the lowest: compounds 1 and 3 (each within the scatter of the next); then compound 2.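

In this assay, 3,4-difluorophenyl in place of 3-cyanophenyl on a sulfonyl sulfur gives a number 18 percentage points lower from compound 2 to compound 3 (beyond the scatter), which shows that a second ring without the nitrile also falls short of compound 2. The two fluorine-bearing rings cannot be told apart here: fluoro in place of methyl on an aromatic carbon gives a number 4 percentage points higher from compound 1 to compound 3 (within the scatter), so this single swap on the ring has no readable effect. No supporting data explain the gap between these rings and the 3-cyanophenyl ring.

As far as these compounds go, whether the higher number of compound 2 belongs to the nitrile itself remains open, and an unsubstituted phenyl ring on the sulfonyl sulfur would be a useful reference point. From the compounds shown here alone, how an amine or a carboxylic acid on this ring would read also stays unknown.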